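This account rests on a few compounds, and the source may have more. Where it says the series, first, only, none or still open, it means among the compounds named here.

Of the compounds shown here, three sharing one core have so far been tested in an assay on HEK293 cells for inhibition of solute carrier family 12 member 2 (Homo sapiens), read by fluorescence, with a stated time of 30 min, tested at 100 uM; a higher number here means a stronger effect of the compound at the concentration tested, a lower number a weaker effect. Compound 1, `CCCCCCCCNc1ccc(C(=O)O)cc1S(N)(=O)=O`, gives 24%. Compound 2, `CC(C)(C)CCNc1ccc(C(=O)O)cc1S(N)(=O)=O`, gives 5.1%. Compound 3, `CCCCCCCCNc1ccc(C(=O)O)cc1S(=O)(=O)NC`, gives 20.1%.

From compound 1 to compound 2 the structure changes in a single place: tert-butyl in place of hexyl on a saturated chain carbon, two bonds along the chain from a nitrogen on an aromatic ring. This change brings a number 18.9 percentage points lower from compound 1 to compound 2 (beyond the scatter), a clear drop. From compound 1 to compound 3 the change is methyl in place of hydrogen on a sulfonamide nitrogen. It brings a number 3.9 percentage points lower from compound 1 to compound 3 (within the scatter), so compound 1 and compound 3 cannot be told apart in this assay.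

Compound 4, `CNS(=O)(=O)c1cc(C(=O)O)ccc1NCCC(C)(C)C`, is not yet measured. It differs from compound 3 by tert-butyl in place of hexyl on a saturated chain carbon, two bonds along the chain from a nitrogen on an aromatic ring. The place is described in exactly the same words as for the move from compound 1 to compound 2, so this is the same change, made on a core that differs from that of compound 1 only by the methyl on the sulfonamide nitrogen already mentioned.

The expectation for compound 4 therefore rests on one measured example: the same change once gave a number 18.9 percentage points lower from compound 1 to compound 2 (beyond the scatter), and the methyl on the sulfonamide nitrogen made no difference that the assay could see. A step of similar size is expected, namely a number 17.1 percentage points lower from compound 3 to compound 4 (beyond the scatter). Compound 4 is estimated to give about 3% in this assay, most likely somewhere between -4% and 12%.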

Compound 4, a percentage reported as inhibition, at one concentration (the size of the read-out at that concentration, not a potency): 2.6%
Compound 4: middle estimate off by 0.4 percentage points, on the high side; the measured number falls inside the stated range.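

In this assay, putting tert-butyl in place of hexyl again gives a clear drop, a number 17.5 percentage points lower from compound 3 to compound 4 (beyond the scatter), and this step matches the one seen on the core of compound 1: the same change on two cores in this assay, a number 18.9 percentage points lower (beyond the scatter) from compound 1 to compound 2 and a number 17.5 percentage points lower (beyond the scatter) from compound 3 to compound 4, 1.4 percentage points apart, within the scatter of two such steps. Methyl in place of hydrogen on the sulfonamide nitrogen gives a number 2.5 percentage points lower from compound 2 to compound 4 (within the scatter), so it again makes no difference the assay can see, and the comparison between the two cores agrees: the same change on two cores in this assay, a number 3.9 percentage points lower (within the scatter) from compound 1 to compound 3 and a number 2.5 percentage points lower (within the scatter) from compound 2 to compound 4, 1.4 percentage points apart, within the scatter of two such steps. Each change therefore carried over between these two cores, but these cores differ only by that one methyl, so nothing here shows that the same would hold on a core that differs more, and readings at a single concentration say nothing about potency.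

From the compounds shown here alone, the chain change alters both the size and the branching of the group, so it remains open whether an unbranched butyl chain would behave like hexyl or like tert-butyl. Going by these compounds, it also remains open whether a larger group on the sulfonamide nitrogen, such as ethyl or benzyl, would stay as invisible in the assay as methyl, or whether an amide in place of the carboxylic acid would shift these readings.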